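Taking the fluoro group off compound 2

The source may hold more compounds than are shown below. What is called first, only, known or untested is meant among the compounds shown, and "the series" means these compounds.

Compound 1 `O=C(COc1ccc(CNC2CC=C(c3c[nH]c4cccc(F)c34)CC2)c(F)c1)NO`: 173 nM
Compound 2 `Cc1[nH]c2cccc(F)c2c1C1=CCC(NCc2ccc(OCC(=O)NO)cc2F)CC1`: 254 nM

Both numbers come from a functional assay on HCT-116 cells (Homo sapiens) for antiproliferative activity, with a stated time of 72 h; on this read-out lower numbers stand for stronger inhibition and higher numbers for weaker inhibition. Going by the values given here, compound 1 is the only measured neighbour of compound 2, so compound 2 at 254 nM can be placed against compound 1 at 173 nM alone, and the two lie within the scatter of each other.

Compound 3 `Cc1[nH]c2ccccc2c1C1=CCC(NCc2ccc(OCC(=O)NO)cc2F)CC1` has not yet been measured. It departs from compound 2 in one place: hydrogen in place of fluoro on an aromatic carbon. In words, this is hydrogen in place of fluoro on an aromatic carbon.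

Among the compounds with values here, no measured pair tests this exact swap. The nearest evidence is a different swap, methyl in place of hydrogen on an aromatic carbon, which gave a 1.5-fold higher number from compound 1 to compound 2 (0.17 log units; within the scatter). That single step is thin support, but it offers no ground for predicting a large shift, so no step beyond the scatter is expected in this assay, in either direction. The expected size of the change is a 1.1-fold lower number from compound 2 to compound 3 (0.02 log units; within the scatter). Compound 3 is estimated at 240 nM, with an expected range of 100 nM to 560 nM.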

Compound 3, half-maximal inhibitory concentration: 99 nM
Estimate against measurement, compound 3: 2.4-fold (0.38 log units) above, and the stated range ends above it.
By their numbers in this assay, from the lowest: compounds 3, 1 and 2 (each within the scatter of the next, the first and the last beyond it).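

In this assay, going by these compounds alone, hydrogen in place of fluoro on an aromatic carbon gives a 2.6-fold lower number from compound 2 to compound 3 (0.41 log units; beyond the scatter) and is the first step in this small set to pass the scatter, so this place on the six-membered aromatic ring, ortho to a fused ring and meta to a fused ring, is one where a single atom can move the read-out. The wider swap, 2-methyl-1H-indol-3-yl in place of 4-fluoro-1H-indol-3-yl, gives a 1.7-fold lower number from compound 1 to compound 3 (0.24 log units; within the scatter) and so leaves compound 3 and compound 1 inseparable, which means the fluoro step shows up here only where the methyl is also present in both partners. Nothing measured here explains why this single swap moves the number.

The compounds shown leave open whether a chloro or a methoxy group at the same place would read like fluoro or like hydrogen. They also leave open whether the same swap of fluoro for hydrogen would give a step of similar size on a core without the methyl, or on one with an ethyl in its place.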